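From compound 3 to compound 4: adding isopropoxy

The source may report more compounds than this note shows. Statements on the series, on what has been measured and on what is new or still open speak of the compounds shown alone.

Compound 1 `COc1c(OC(C)C)cc2occ(-c3csc4ccccc34)c(=O)c2c1O` gives > 10000 nM as a limit, not a number.
Compound 2 `O=c1c(-c2csc3ccccc23)coc2ccccc12` gives > 10000 nM as a limit, not a number.
Compound 3 `O=C(/C=C/c1csc2ccccc12)c1ccccc1O` gives 6600 nM as a number.

All three were tested in a functional assay on MCF7 cells (Homo sapiens) for antiproliferative activity, read by sulforhodamine B assay, with a stated time of 72 h; on this read-out lower numbers stand for stronger inhibition and higher numbers for weaker inhibition. Compound 3 is the only one of them with a number rather than a limit. Compound 4 `CC(C)Oc1ccc(O)c(C(=O)/C=C/c2csc3ccccc23)c1` is still unmeasured. It differs from compound 3 by isopropoxy in place of hydrogen on an aromatic carbon, on a six-membered aromatic ring of carbon only. Among the measured compounds shown here, with no measured step to go by, only a small change is expected in this assay, an estimated 1.3-fold lower number from compound 3 to compound 4 (0.12 log units; within the scatter), perhaps none beyond the scatter. The value expected for compound 4 is 5000 nM, with an estimated range from 1800 nM to 14000 nM.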

Compound 4, half-maximal inhibitory concentration: 6600 nM
Compound 4: the middle estimate sits 1.3-fold (0.12 log units) below what was measured; the range from low to high includes it.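

Placed para to a hydroxy group on the six-membered aromatic ring of carbon only, isopropoxy gives no change at the digits printed from compound 3 to compound 4 (within the scatter) in this assay and so leaves the antiproliferative read-out where it stood. This single step shows that this position accepts isopropoxy in place of hydrogen without a change beyond the scatter. Nothing shown gives a cause for this flat step.

From the compounds shown here alone, whether an amine or a carboxylic acid at this position would move the value remains open. So does the effect of a longer chain than isopropoxy on the same aromatic carbon.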